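Adding a phenyl to the ring methyl: compound 4 expected

A few compounds are considered here, and "the series" means these few. Any claim that something is new, unique, unknown or untested is made for them only; others in the source may bear on it.

Measured so far:
compound 1 `N#Cc1c(-c2ccc(O)cc2)nc(SCC(=O)Nn2c(COc3ccc(Cl)cc3Cl)nc3ccccc3c2=O)[nH]c1=O` 61.5%
compound 2 `N#Cc1c(-c2ccccc2)nc(SCC(=O)Nn2c(COc3ccc(Cl)cc3Cl)nc3ccccc3c2=O)n(Cc2ccccc2)c1=O` 76%
compound 3 `Cn1c(SCC(=O)Nn2c(COc3ccc(Cl)cc3Cl)nc3ccccc3c2=O)nc(-c2ccc(O)cc2)c(C#N)c1=O` 76.9%

In a functional assay on the whole organism (strain albino) for inhibition, with Rattus norvegicus as the target, read by paw edema, with stated times of 1 h and 0.5 h, at a dose of 100 mg/kg by the oral route (a lower number here means less inhibition, a higher number more inhibition at the dose given (going by the name of the read-out)), compound 3 gives the highest of the three numbers; compound 2 sits within the scatter of it, while compound 1 lies beyond it. Compound 4 `N#Cc1c(-c2ccc(O)cc2)nc(SCC(=O)Nn2c(COc3ccc(Cl)cc3Cl)nc3ccccc3c2=O)n(Cc2ccccc2)c1=O` carries the change (phenyl in place of hydrogen on a saturated chain carbon bound to an aromatic nitrogen); cut one bond further out, this reads methyl to benzyl. Among the measured compounds shown here, the only single-place step known is a number 15.4 percentage points higher from compound 1 to compound 3 (beyond the scatter), which concerns a different change and does not carry over. Compound 2, which also bears a benzyl on that nitrogen, gives 76%, close to compound 3. The expected step is therefore a number 0.9 percentage points lower from compound 3 to compound 4 (within the scatter), none beyond the scatter. Compound 4 is estimated at 76%, within 65% to 86%.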

Compound 4, a percentage reported as inhibition, in the whole organism at one dose (the size of the read-out at that dose, not a potency): 51.9%
Beside the measured number, compound 4's estimate is 24.1 percentage points above it; measured number below the stated range.
By their numbers in this assay, from the lowest: compounds 4 and 1 (each within the scatter of the next); then compounds 2 and 3 (each within the scatter of the next).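

In this assay a larger group on this nitrogen does not keep what methyl gave: benzyl in place of methyl brings a number 25 percentage points lower from compound 3 to compound 4 (beyond the scatter), and benzyl in place of hydrogen gives a number 9.6 percentage points lower from compound 1 to compound 4 (within the scatter), so the gain of a number 15.4 percentage points higher from compound 1 to compound 3 (beyond the scatter) does not extend to benzyl. With benzyl on the nitrogen, the hydroxy on the aromatic carbon also matters, with a number 24.1 percentage points lower from compound 2 to compound 4 (beyond the scatter). No available data explain either drop. Still open, as far as these compounds go, is how an ethyl chain on this nitrogen would read, and whether an amine on the benzyl ring would shift the number.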